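This account rests on a few compounds, and the source may have more. Where it says the series, first, only, none or still open, it means among the compounds named here.

Compound 1 `Cc1cccc(/C(N)=N/NC(=S)N2CCSCC2)n1` was tested in a functional assay on A-375 cells (Homo sapiens) for cytotoxicity, read by MTT assay, with a stated time of 72 h, tested at 3 uM (a lower number here means less inhibition of growth, a higher number more inhibition of growth at the concentration tested), and gives 60.1%. Compound 2 `N/C(=N\NC(=S)N1CCSCC1)c1ccccn1` differs from it in a single place, (hydrogen in place of methyl on an aromatic carbon), and in this assay compound 2 gives 80%; this change made a step of a number 19.9 percentage points higher from compound 1 to compound 2 (beyond the scatter). Compound 3 `Cc1cccc(/C(N)=N/NC(=S)N2CCCC2)n1` keeps the methyl of compound 1 but has a different core, (pyrrolidin-1-yl in place of thiomorpholin-4-yl on a thiocarbonyl carbon). In this assay compound 3 gives 51.3%, a step of a number 8.8 percentage points lower from compound 1 to compound 3 (within the scatter), so the two cores are not told apart by this measurement. Compound 4 `N/C(=N\NC(=S)N1CCCC1)c1ccccn1` has not yet been measured. It stands to compound 3 exactly as compound 2 stands to compound 1, through the same change at the same place, (hydrogen in place of methyl on an aromatic carbon). The expectation for it rests on compound 1 and compound 2, whose step a number 19.9 percentage points higher from compound 1 to compound 2 (beyond the scatter) lay beyond the scatter, and on the core change a number 8.8 percentage points lower from compound 1 to compound 3 (within the scatter), which stayed within it. The expected step is a number 18.7 percentage points higher from compound 3 to compound 4 (beyond the scatter). Compound 4 is therefore estimated to give 70%, most likely between 56% and 84%.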

Compound 4, percent growth inhibition at one concentration: 80%
For compound 4 the middle estimate is 10 percentage points below the measured one, within the range that was stated.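

On the second core, hydrogen in place of methyl gave a number 28.7 percentage points higher from compound 3 to compound 4 (beyond the scatter), so in this assay the change carried over from one core to the other, and the two steps cannot be told apart in size: the same change on two cores in this assay, a number 19.9 percentage points higher (beyond the scatter) from compound 1 to compound 2 and a number 28.7 percentage points higher (beyond the scatter) from compound 3 to compound 4, 8.8 percentage points apart, within the scatter of two such steps

The swap of cores gave no change at the digits printed from compound 2 to compound 4 (within the scatter), and it looks the same with the methyl or with hydrogen at that place: the same change on two cores in this assay, a number 8.8 percentage points lower (within the scatter) from compound 1 to compound 3 and no change at the digits printed (within the scatter) from compound 2 to compound 4, 8.8 percentage points apart, within the scatter of two such steps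

For the compounds shown here, this rests on only two cores, one cell line and one concentration, so it gives no rule for other cores and does not show why the step occurs.

The compounds shown carry only hydrogen or methyl at this place on the aromatic ring, so it stays open what an ethyl, a methoxy or an amine there would give. The thiocarbonyl carbon carries only pyrrolidin-1-yl or thiomorpholin-4-yl, which leaves open what an open-chain group such as diethylamino would give.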